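The source may report more compounds than this note shows. Statements on the series, on what has been measured and on what is new or still open speak of the compounds shown alone.

Measured in a functional assay on HeLa cells (Homo sapiens) for antiproliferative activity, read by MTT assay, with a stated time of 48 h; a lower number here means a stronger inhibitor, a higher number a weaker inhibitor:
- compound 1 `CNCC(=O)Nc1cc(OC)ccc1C(=O)c1ccc(OC)c2c1OC(C)(C)C=C2`: 870 nM
- compound 2 `COc1ccc(C(=O)c2ccc(OC)c3c2OC(C)(C)C=C3)c(NC(=O)CN(C)C)c1`: 1050 nM
- compound 3 `C=C(c1ccc(OC)cc1NC(=O)CN)c1ccc(OC)c2c1C=CC(C)(C)O2`: 200 nM

Compound 3 gives the lowest number of the three at 200 nM, and its gaps to compound 1 and compound 2 both lie beyond the scatter. Compound 4 `C=C(c1ccc(OC)cc1NC(=O)CN(C)C)c1ccc(OC)c2c1C=CC(C)(C)O2` is not yet measured. It differs from compound 3 as follows: dimethylamino in place of amino on a saturated chain carbon bound to a carbonyl carbon.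

For the measured compounds named here, the one measured step that bears on this is a 1.2-fold higher number from compound 1 to compound 2 (0.08 log units; within the scatter), with methyl in place of hydrogen on an amine nitrogen. That step lies within the scatter, but it is an indirect guide: it starts from a different amine on a different core. Going by the values given here, no measured pair shows amino going directly to dimethylamino.

A similarly small change is therefore expected in this assay, and the estimated step is a 1.2-fold higher number from compound 3 to compound 4 (0.08 log units; within the scatter). For compound 4 the estimate is 240 nM, with an expected range of 110 nM to 500 nM.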

Compound 4, half-maximal inhibitory concentration: 790 nM
Estimate against measurement, compound 4: 3.3-fold (0.52 log units) below, and the stated range ends below it.
By their numbers in this assay, from the lowest: compound 3; then compounds 4, 1 and 2 (each within the scatter of the next).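

In this assay the end of the side chain on the core of compound 3 proves sensitive to substitution: dimethylamino in place of amino on a saturated chain carbon bound to a carbonyl carbon gives a 4.0-fold higher number from compound 3 to compound 4 (0.60 log units; beyond the scatter). The earlier step, a 1.2-fold higher number from compound 1 to compound 2 (0.08 log units; within the scatter), with methyl in place of hydrogen on an amine nitrogen, starts from a different amine on a different core, and its small size does not carry over to this change on this core. Nothing available explains the size of the new step.

From the compounds shown here alone, it remains open whether the higher number follows the larger group or the loss of the hydrogen-bond donor. Diethylamino, a pyrrolidine ring or a hydroxyl group at the same place on the core of compound 3 would help separate these readings.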